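This account rests on a few compounds, and the source may have more. Where it says the series, first, only, none or still open, it means among the compounds named here.

Measured in a functional assay (aorta) with Oryctolagus cuniculus as the target; on this read-out higher numbers stand for weaker binding and lower numbers for tighter binding:
- compound 1 `COc1cc(C(C)O)ccc1OCCCN1CCC(C(c2ccc(F)cc2)c2ccc(F)cc2)CC1`: 10 nM
- compound 2 `COC(=O)c1ccc(OCCCN2CCC(C(c3ccc(F)cc3)c3ccc(F)cc3)CC2)c(OC)c1`: 1.26 nM

Compound 2, at 1.26 nM, has the lower of these two numbers. Compound 3 `COc1cc(C(=O)O)ccc1OCCCN1CCC(C(c2ccc(F)cc2)c2ccc(F)cc2)CC1` departs from it in a single place: hydrogen in place of methyl on an oxygen next to a carbonyl group. This puts hydrogen in place of methyl on an oxygen next to a carbonyl group, so methoxycarbonyl becomes carboxy.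

Going by the values given here, only one measured step bears on this change: a 7.9-fold lower number from compound 1 to compound 2 (0.90 log units; beyond the scatter). There, methoxycarbonyl took the place of 1-hydroxyethyl on an aromatic carbon. This modest step lies beyond the scatter and shows that the read-out can respond when the methoxycarbonyl group is replaced. Among the compounds with values here, no measured compound carries carboxy, so the size of the new step cannot be read directly from the data. Since compound 1, at 10 nM, is the only measured replacement for the methoxycarbonyl group and has the higher number, a higher number is also expected here, with a step of similar size. The expected change is a 9.5-fold higher number from compound 2 to compound 3 (0.98 log units; beyond the scatter). The estimated value for compound 3 is 12 nM, with an expected range of 2.5 nM to 60 nM.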

Compound 3, dissociation constant: 79.4 nM
Compound 3: middle estimate off by 6.6-fold (0.82 log units), on the low side, outside the stated range (above it).
By their numbers in this assay, from the lowest: compound 2; then compound 1; then compound 3.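

In this assay, a change of only methyl to hydrogen on an oxygen next to a carbonyl group gives a 63-fold higher number from compound 2 to compound 3 (1.80 log units; beyond the scatter) and so turns methoxycarbonyl into carboxy. This shows that the read-out at this aromatic carbon depends strongly on that one methyl, and that two groups which both carry a carbonyl can lie far apart, whereas the earlier pair showed only that 1-hydroxyethyl and methoxycarbonyl differ. Carboxy also separates from 1-hydroxyethyl, with a 7.9-fold higher number from compound 1 to compound 3 (0.90 log units; beyond the scatter) in the same direction, which places the three groups at this carbon in the order methoxycarbonyl, 1-hydroxyethyl, carboxy from lowest number to highest, with every gap beyond the scatter; no information is at hand that would account for this order.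

Open, as far as these compounds go, is whether the low number of compound 2 needs the methyl specifically or would persist with a longer chain on the same oxygen, such as ethoxycarbonyl. Also open, from the compounds shown here alone, is where a primary amide or a hydroxymethyl group at this aromatic carbon would fall relative to these three groups.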